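Agonist maximal response: alkoxy versus isopropyl on the terminal ring

The source may report more compounds than this note shows. Statements on the series, on what has been measured and on what is new or still open speak of the compounds shown alone.

Measured so far in an assay on cells for agonist activity at Free fatty acid receptor 1 (Rattus norvegicus), read by a beta-galactosidase reporter and beta-arrestin recruitment, with a stated time of 90 min, in the presence of a further agent that is not named here; a lower number here means a smaller maximal response, a higher number a larger maximal response:
compound 1 `CC#C[C@@H](CC(=O)O)c1ccc(OCc2ccc3nc(-c4ccc(OC(F)F)cc4)nn3c2)cc1` gives 142%
compound 2 `CC#C[C@@H](CC(=O)O)c1ccc(OCc2ccc3nc(-c4c(C)cc(OCCCS(C)(=O)=O)cc4C)nn3c2)cc1` gives 140%
compound 3 `CC#C[C@@H](CC(=O)O)c1ccc(OCc2ccc3nc(-c4ccc(C(C)C)cc4)nn3c2)cc1` gives 123%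

Compound 3 stands lowest of the three; compound 2 and compound 1 both lie beyond the scatter above it. For the measured compounds named here, the one relevant measured step is a number 19 percentage points lower from compound 1 to compound 3 (beyond the scatter), which runs from an oxygen-linked group to a carbon-only group. Compound 4 `CC#C[C@@H](CC(=O)O)c1ccc(OCc2ccc3nc(-c4ccc(OCCOC)cc4)nn3c2)cc1` reverses that direction: 2-methoxyethoxy in place of isopropyl on an aromatic carbon. Going by the values given here, compound 2 carries an oxygen-linked chain on the same kind of position and sits near compound 1, though no single step connects it to compound 3. A rise of about that size is therefore expected, a number 15 percentage points higher from compound 3 to compound 4 (beyond the scatter), giving compound 4 an estimated 138% in this assay, within 122% to 152%.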

Compound 4, largest response reached (reported as percent of maximum), in percent of the reference or control that the assay uses: 133%
Estimate against measurement, compound 4: 5 percentage points above, and the stated range covers the measured number.
By their numbers in this assay, from the lowest: compounds 3, 4, 2 and 1 (each within the scatter of the next, the first and the last beyond it).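

In this assay the 2-methoxyethoxy group on this aromatic carbon gives a number 10 percentage points higher from compound 3 to compound 4 (within the scatter) and also a number 9 percentage points lower from compound 1 to compound 4 (within the scatter), so compound 4 separates from neither compound, although compound 1 and compound 3 lie beyond the scatter of each other. An oxygen link on this ring position therefore does not by itself give a step from isopropyl that clears the scatter. Nothing measured here bears on the reason for these numbers.

As far as these compounds go, whether a terminal amine or carboxylic acid on this chain, or a longer alkoxy chain, would keep this maximal response remains open. Also open, from the compounds shown here alone, is whether the gap between compound 1 and compound 3 follows the linking oxygen or the difluoromethyl group.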